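Dimethylamino for amino on the aryl urea

A few compounds are considered here, and "the series" means these few. Any claim that something is new, unique, unknown or untested is made for them only; others in the source may bear on it.

Compound 1, `O=C(Nc1ccncc1)Nc1ccccc1Br`: in a functional assay on the whole organism with Mus musculus as the target, in the maximal electroshock model, with a stated time of 30 min (a lower number here means that less compound is needed, a higher number that more compound is needed for the effect), compound 1 gives 100 mg/kg.
Compound 2, `Nc1ccccc1NC(=O)Nc1ccncc1`: in this assay compound 2 gives > 300 mg/kg, a limit of the measurement and not a number.

Compound 2 stands at the limit of > 300 mg/kg in this assay, at which 1 of the 2 values shown sits. Going by the values given here, its only neighbour is compound 1, and the one measured step, an at least 3.0-fold higher number from compound 1 to compound 2 (0.47 log units; beyond the scatter), goes from a number to that limit. The next compound, compound 3, `CN(C)c1ccccc1NC(=O)Nc1ccncc1`, changes the same position again: dimethylamino in place of amino on an aromatic carbon. Among the compounds with values here, no measured step describes this exact change, so the only guide is that compound 2 already needs more than the amount tested. Compound 3 is therefore expected to stay near that limit, with a number no higher from compound 2 to compound 3 (the limit leaves the size open) as the estimated step. The minimum effective dose expected for compound 3 is 300 mg/kg, within a range from 100 mg/kg to 900 mg/kg, with a fair chance that only a limit is reported.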

Compound 3, minimum effective dose: 100 mg/kg
Estimate against measurement, compound 3: 3.0-fold (0.48 log units) above; low and high end bracket the measured number.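

Swapping amino for dimethylamino on this aromatic carbon gives an at least 3.0-fold lower number from compound 2 to compound 3 (0.47 log units; beyond the scatter) in this assay, so the drop seen with amino is not a general result for nitrogen groups at this position. Dimethylamino also matches bromo, with no change at the digits printed from compound 1 to compound 3 (within the scatter), which means two quite different groups give the same printed dose here, and only amino, in compound 2, goes against this. The change swaps a group with one hydrogen-bond donor for a larger one with none, and this single step cannot separate those two differences.

As far as these compounds go, the true size of the step stays open, since compound 2 gives only a limit of the measurement and not a number: the limit of > 300 mg/kg in this assay, at which 1 of the 3 values shown sits. Methylamino, which has a single methyl on the nitrogen, and methoxy would be the groups to place on this scale.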